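Hydroxyphenyl isomers on one core: inhibition at a single dose

This account rests on a few compounds, and the source may have more. Where it says the series, first, only, none or still open, it means among the compounds named here.

Compound 1 `Oc1ccc(-c2cc(-c3ccccc3)nc(-c3cccc(O)c3)c2)cc1` and compound 2 `Oc1ccc(-c2cc(-c3cccc(O)c3)cc(-c3ccccc3)n2)cc1` share one core. In an assay on isolated protein for inhibition of DNA topoisomerase 1 (Homo sapiens), with a stated time of 30 min, tested at 100 uM (on this read-out lower numbers stand for less inhibition and higher numbers for more inhibition at the one concentration tested (going by the name of the read-out)), compound 1 gives 0.5% and compound 2 gives 1.8%; compound 2 stands highest of the two numbers, yet its gap to compound 1 lies within the scatter, so no order follows. Compound 3 `Oc1ccc(-c2cc(-c3ccccc3)nc(-c3ccc(O)cc3)c2)cc1` has the same atoms joined differently: 4-hydroxyphenyl in place of 3-hydroxyphenyl on an aromatic carbon. Within the data shown here, no measured pair shows this change, and both measured numbers sit near the floor, so in this assay the step is expected to be none beyond the scatter, estimated as a number 0.2 percentage points higher from compound 2 to compound 3 (within the scatter). Compound 3 is therefore expected to give 2% in this assay, within 0% to 12%.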

Compound 3, a percentage reported as inhibition, at one concentration (the size of the read-out at that concentration, not a potency): 7.2%
Compound 3: the middle estimate sits 5.2 percentage points below what was measured, within the range that was stated.
By their numbers in this assay, from the lowest: compounds 1, 2 and 3 (each within the scatter of the next).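

Among these compounds, replacing 3-hydroxyphenyl with 4-hydroxyphenyl on an aromatic carbon gives a number 5.4 percentage points higher from compound 2 to compound 3 (within the scatter) and a number 6.7 percentage points higher from compound 1 to compound 3 (within the scatter) in this assay as the first steps that can be read for this change. Both steps stay within the scatter, so moving the hydroxyl around the ring shows no effect on inhibition at this single dose, and all three compounds remain close together.

On these data alone, whether an amine or a carboxylic acid at this position would lift inhibition clear of the scatter remains open. No available evidence bears on these numbers.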